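A few compounds are considered here, and "the series" means these few. Any claim that something is new, unique, unknown or untested is made for them only; others in the source may bear on it.

Compound 1 `CCC(c1ccc(Br)cc1)(C(C)O)n1ncc2c(NS(C)(=O)=O)cccc21` half-life 1.15 h
Compound 2 `CCC(O)C(CC)(c1ccc(C(F)(F)F)cc1)n1ncc2c(NS(C)(=O)=O)cccc21` half-life > 1.5 h (a limit of the assay, not a number)

Both values come from an ADME assay on cells (Hepatocyte, Homo sapiens) for metabolic stability (on this read-out lower numbers stand for a shorter-lived compound and higher numbers for a longer-lived compound), and together make up all that has been measured so far. Compound 2 sits at the limit of > 1.5 h in this assay, at which 1 of the 2 values shown sits, and therefore carries no exact number. Compound 3 `CCC(c1ccc(C(F)(F)F)cc1)(C(O)C(F)F)n1ncc2c(NS(C)(=O)=O)cccc21` has not yet been measured. Its difference from compound 2 is difluoromethyl in place of ethyl on a saturated chain carbon bound to an oxygen on a saturated carbon and a saturated chain carbon and lies in one place: difluoromethyl in place of ethyl on a saturated chain carbon bound to an oxygen on a saturated carbon and a saturated chain carbon, which turns 1-hydroxypropyl into 2,2-difluoro-1-hydroxyethyl. Among the measured compounds shown here, no measured pair shows this change, so the expectation is a loose one. In this assay the expected step of a number no higher from compound 2 to compound 3 (the limit leaves the size open) is none beyond the scatter, with neither direction favoured. Compound 3 is estimated at 1.5 h with an expected range from 0.8 h to 2.8 h in this measurement.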

Compound 3, half-life: > 1.5 h
Compound 3 was reported as a limit (the forecaster's own chance of this, stated with the estimate: 50%); the middle value lies on the limit itself.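

In this assay, among the compounds shown here, compound 2 and compound 3 both stand at a limit of the assay, not at a number, so no step between them can be read: the limit of > 1.5 h in this assay, at which 2 of the 3 values shown sit. The compounds shown leave open whether difluoromethyl in place of ethyl alters the half-life at all.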